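The compounds below may be only part of what the source reports. "The series", "measured", "known", "first", "only" and "open" are said of these compounds alone.

Measured in a functional assay on HEK293 cells for antagonist activity at metabotropic glutamate receptor 5 (Homo sapiens), read by FLIPR and calcium flux; on this read-out lower numbers stand for stronger inhibition and higher numbers for weaker inhibition:
Compound 1, `COc1ccc(C(=O)N[C@H]2CCC[C@H](NC(=O)c3cccc(Cl)c3)C2)cc1`, gives 266 nM.
Compound 2, `CN(C)c1ccc(C(=O)N[C@H]2CCC[C@H](NC(=O)c3cccc(Cl)c3)C2)cc1`, gives 473 nM.
Compound 3, `O=C(N[C@H]1CCC[C@H](NC(=O)c2ccccn2)C1)c1cccc(Cl)c1`, gives only a limit of the assay, > 10000 nM.

Going by the values given here, compound 3 thus sits at the limit of > 10000 nM in this assay, at which 1 of the 3 values shown sits, and is the one compound of the three without a number. Among the compounds with values here, the steps of an at least 37-fold higher number from compound 1 to compound 3 (1.57 log units; beyond the scatter) and an at least 21-fold higher number from compound 2 to compound 3 (1.32 log units; beyond the scatter) both swap the whole aryl group on that carbonyl and are large; nothing measured alters the pyridin-2-yl ring itself, so no step bears directly on the next change.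

Compound 4 is `Cc1cccnc1C(=O)N[C@H]1CCC[C@H](NC(=O)c2cccc(Cl)c2)C1`; the change from compound 3 is methyl in place of hydrogen on an aromatic carbon. With compound 3 at a limit, only a small move is expected for compound 4 in this assay, a step that the limit leaves unreadable from compound 3 to compound 4, most likely again a limit. The estimate for compound 4 is 12000 nM, range 2500 nM to 50000 nM.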

Compound 4, half-maximal inhibitory concentration: 7840 nM
Estimate against measurement, compound 4: 1.5-fold (0.18 log units) above; the measured number falls inside the stated range.
By their numbers in this assay, from the lowest: compounds 1 and 2 (each within the scatter of the next); then compound 4. At a limit, above all of these: compound 3.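

In this assay, methyl on the aromatic carbon ortho to a large group gives the pyridin-2-yl series a measured number, but the step reads only as an at least 1.2-fold lower number from compound 3 to compound 4 (0.10 log units; that floor lies within the scatter) in this comparison. From the compounds shown here alone, compound 3 stands at a limit of the assay, and the true size of this step stays unknown because of that limit: the limit of > 10000 nM in this assay, at which 1 of the 4 values shown sits.
The 3-methylpyridin-2-yl group remains far from the two substituted phenyl groups, with a 17-fold higher number from compound 2 to compound 4 (1.22 log units; beyond the scatter) and a 29-fold higher number from compound 1 to compound 4 (1.47 log units; beyond the scatter) at the same carbonyl.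

Going by these compounds, whether a longer chain such as ethyl, or a methoxy group or an amine, at this position would move the number further remains open. Methyl at the other carbons of the pyridine ring also remains open.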